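This account rests on a few compounds, and the source may have more. Where it says the series, first, only, none or still open, it means among the compounds named here.

Among the measured compounds shown here, compound 1 `O=C(C1CCC(F)(F)CC1)N1CC(c2nc(-c3cccc(F)c3)no2)C1` sits at the weaker end of the two measured members: in an assay on HEK293 cells for positive allosteric modulation of metabotropic glutamate receptor 5 (Homo sapiens), read by FLIPR (a higher number here means that more compound is needed for the effect, a lower number that less compound is needed), compound 1 gives 520 nM, whereas compound 2 `O=C(C1CCC(F)(F)CC1)N1CC(c2nc(-c3cccc(Cl)c3)no2)C1` gives 180 nM. For the measured compounds named here, the only measured step, a 2.9-fold lower number from compound 1 to compound 2 (0.46 log units; beyond the scatter), concerns the halogen on the aromatic ring and leaves the carbonyl side of the shared core untouched. Going by the values given here, compound 3 `O=C([C@@H]1CC2CCC1C2)N1CC(c2nc(-c3cccc(F)c3)no2)C1` changes that other side instead: a group of 7 heavy atoms (7 carbon; 2 five-membered non-aromatic rings of carbon only) in place of a group of 8 heavy atoms (6 carbon, 2 fluorine; one six-membered non-aromatic ring of carbon only), on a carbonyl carbon No measured step bears on this position, so the numbers give no guide to how the group on the carbonyl carbon sets the read-out, and the expectation rests on compound 1 alone. For compound 3 the step of a 1.2-fold higher number from compound 1 to compound 3 (0.06 log units; within the scatter) is expected to be small, in either direction, because compound 1 gives 520 nM and nothing measured argues for a move away from it. Compound 3 is therefore estimated at 600 nM, with a wide range from 200 nM to 2000 nM.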

Compound 3, half-maximal effective concentration: 100 nM
Compound 3: the middle estimate sits 6.0-fold (0.78 log units) above what was measured; measured number below the stated range.
By their numbers in this assay, from the lowest: compounds 3 and 2 (each within the scatter of the next); then compound 1.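

In this assay the group on the carbonyl carbon proves to matter: with the halogen on the aromatic ring unchanged, exchanging 4,4-difluorocyclohexyl for the all-carbon group with 2 five-membered non-aromatic rings gives a 5.2-fold lower number from compound 1 to compound 3 (0.72 log units; beyond the scatter). The carbonyl side is thus a second place, alongside the halogen on the aromatic ring, where a single change moves the number beyond the scatter, and the fluorines of the leaving group are not required for a low number in this pair. Nothing available here accounts for the size or direction of this step.

This one step changes the ring system, the fluorine count and the defined stereocentre together, so their separate contributions remain unresolved; unsubstituted cyclohexyl and the opposite stereoisomer would separate them. Also open, on these data alone, is whether the chloro change adds to this one when both are combined in a single compound.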